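The source may hold more compounds than are shown below. What is called first, only, known or untested is meant among the compounds shown, and "the series" means these compounds.

Measured compounds:
- compound 1 `C=CC1=C(C(=O)NCc2ccccc2)C(c2ccc(OC)cc2)OC1`; in a functional assay on A549 cells (Homo sapiens) for cytotoxicity, read by MTT assay, with a stated time of 24 h (a lower number here means a stronger inhibitor, a higher number a weaker inhibitor), compound 1 gives > 100000 nM, a limit of the assay.
- compound 2 `C=CC1=C(C(=O)NCc2ccc(C)cc2)C(c2ccc(F)cc2)OC1`; in this assay compound 2 gives > 100000 nM, again only a limit.
- compound 3 `C=CC1=C(C(=O)NCC(C)C)C(c2ccc(OC)cc2)OC1`; in this assay compound 3 gives > 100000 nM, also a limit.

For the measured compounds named here, compound 3 therefore stands nowhere on a readable scale: its value is a limit, as is every value so far, see (the limit of > 100000 nM in this assay, at which 3 of the 3 values shown sit). Going by the values given here, the one single-point step, a step that the two limits leave unreadable from compound 1 to compound 3, is unreadable for the same reason.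

Compound 4 `C=CC1=C(C(=O)NCc2ccc(C)cc2)C(c2ccc(OC)cc2)OC1` carries the change (4-methylphenyl in place of isopropyl on a saturated chain carbon bound to an amide-type nitrogen). The 4-methylbenzyl amide already occurs in compound 2, paired with a different aryl, and the methoxyphenyl already occurs in compound 1 and compound 3; none of these gave a number. Among the compounds with values here, no measured step bears readably on the change, so no direction can be set for this assay; the expectation is that compound 4 also sits at the limit. For compound 4 the estimate is 150000 nM, range 30000 nM to 1000000 nM. The step from compound 3 to compound 4 is expected to be a step that the limit leaves unreadable from compound 3 to compound 4, that is, not readable.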

Compound 4, half-maximal inhibitory concentration: > 100000 nM
Compound 4 gave a limit, no number; the forecaster's own chance of this, stated with the estimate: 85%; the middle value does not contradict the limit.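

In this assay compound 4 again gives only a limit, so no step among compound 1, compound 2, compound 3 and compound 4 can be read: the limit of > 100000 nM in this assay, at which 4 of the 4 values shown sit.

The compounds shown leave open whether any substituent on the shared core gives a readable value in this assay at all.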